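Swapping Chloro for Bromo on the Pendant Ring

A few compounds are considered here, and "the series" means these few. Any claim that something is new, unique, unknown or untested is made for them only; others in the source may bear on it.

Compound 3 `COC(=O)C[C@H](O)C[C@H](O)/C=C/n1c(C(C)C)cc(-c2ccc(F)cc2)c1-c1cccc(Cl)c1` gives 71 nM in an assay for inhibition of 3-hydroxy-3-methylglutaryl-coenzyme A reductase (Rattus norvegicus), using microsomes (a lower number here means a stronger inhibitor, a higher number a weaker inhibitor), the highest number among the three measured compounds. Compound 1 `COC(=O)C[C@H](O)C[C@H](O)/C=C/n1c(C(C)C)cc(-c2ccc(F)cc2)c1-c1ccccc1` gives 25 nM in this assay, and compound 2 `COC(=O)C[C@H](O)C[C@H](O)/C=C/n1c(C(C)C)cc(-c2ccncc2)c1-c1ccc(F)cc1` gives 5 nM in this assay. For the measured compounds named here, the only measured step, a 2.8-fold higher number from compound 1 to compound 3 (0.45 log units; beyond the scatter), is the one that introduces the chloro which compound 4 `COC(=O)C[C@H](O)C[C@H](O)/C=C/n1c(C(C)C)cc(-c2ccc(F)cc2)c1-c1cccc(Br)c1` now replaces: bromo in place of chloro on an aromatic carbon. Going by the values given here, no measured pair shows an exchange of chloro for bromo, so nothing measured bears directly on this change, and the two halogens are counted the same way. The step of a 1.1-fold higher number from compound 3 to compound 4 (0.05 log units; within the scatter) is therefore expected to stay within the scatter of this assay. Compound 4 is expected to give about 80 nM, with a range from 35 nM to 180 nM.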

Compound 4, half-maximal inhibitory concentration: 69 nM
Compound 4: middle estimate off by 1.2-fold (0.06 log units), on the high side, and the stated range covers the measured number.
By their numbers in this assay, from the lowest: compound 2; then compound 1; then compounds 4 and 3 (each within the scatter of the next).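

In this assay, the exchange of chloro for bromo now has a measured pair, and a 1.0-fold lower number from compound 3 to compound 4 (0.01 log units; within the scatter) shows that the two halogens cannot be told apart at this place. Bromo in place of hydrogen gives a 2.8-fold higher number from compound 1 to compound 4 (0.44 log units; beyond the scatter), a step of about the same size as a 2.8-fold higher number from compound 1 to compound 3 (0.45 log units; beyond the scatter), so in these compounds either halogen goes with a weaker inhibitor than hydrogen. No measurement shown explains this match between the halogens.

As far as these compounds go, what a methoxy group or an amine would do at this place stays open. Also open, from the compounds shown here alone, is whether the halogen step carries over to the core of compound 2.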